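The compounds below may be only part of what the source reports. "The series", "measured", "known", "first", "only" and "open" are said of these compounds alone.

Measured in a functional assay on SW-620 cells (Homo sapiens) for antiproliferative activity, read by MTT assay, with a stated time of 72 h; on this read-out lower numbers stand for stronger inhibition and higher numbers for weaker inhibition:
Compound 1 `C(=C/c1nc2ncccc2[nH]1)\c1ccccc1`, 4640 nM.
Compound 2 `Clc1ccccc1/C=C/c1nc2ncccc2[nH]1`, 50900 nM.
Compound 3 `N#Cc1ccc(/C=C/c2nc3ncccc3[nH]2)cc1`, a limit of the assay, > 100000 nM.

Compound 3 therefore stands at the limit of the assay, (the limit of > 100000 nM in this assay, at which 1 of the 3 values shown sits), with no number of its own. Compound 4 `N#Cc1ccc(/C=C/c2nc3ncc(Br)cc3[nH]2)cc1` differs from compound 3 by bromo in place of hydrogen on an aromatic carbon. The measured steps concern the other ring: an 11-fold higher number from compound 1 to compound 2 (1.04 log units; beyond the scatter) and an at least 21-fold higher number from compound 1 to compound 3 (1.33 log units; beyond the scatter) were both large, but neither touches the place changed here, so they give no direct guide. The step of a number no higher from compound 3 to compound 4 (the limit leaves the size open) is expected to stay within the scatter. Compound 4 is estimated at 100000 nM, within 30000 nM to 300000 nM, and may well be reported again only as a limit.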

Compound 4, half-maximal inhibitory concentration: 7110 nM
Compound 4: the middle estimate sits 14-fold (1.15 log units) above what was measured; measured number outside the range, below it.
By their numbers in this assay, from the lowest: compounds 1 and 4 (each within the scatter of the next); then compound 2. At a limit, above all of these: compound 3.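

In this assay, bromo on the aromatic carbon two atoms from the ring nitrogen gives an at least 14-fold lower number from compound 3 to compound 4 (1.14 log units; beyond the scatter), so this position on the core can carry a large change in the read-out. The earlier steps shown here, on the other ring, both went to higher numbers, while this one goes lower even with the cyano group kept. The true size remains a bound, as compound 3 has only a limit: the limit of > 100000 nM in this assay, at which 1 of the 4 values shown sits.

On these data alone, whether a methyl or an amine at this position would do the same remains open. So does whether bromo would have a similar effect on compound 1, which lacks the cyano group.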